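Methoxy in Place of Iodo: What the Writhing Test Might Show

The source may hold more compounds than are shown below. What is called first, only, known or untested is meant among the compounds shown, and "the series" means these compounds.

Of the compounds shown here, two have been measured in a functional assay on the whole organism with Mus musculus as the target, in the writhing test; a lower number here means that less compound is needed, a higher number that more compound is needed for the effect. Compound 1 `CCOC(=O)N1CCC(Sc2c[nH]c3ccc(Br)cc23)CC1` gives 6.3 mg/kg, while compound 2 `CN1CCC(Sc2c[nH]c3ccc(I)cc23)CC1` gives 54.2 mg/kg, the higher of the two numbers and beyond the scatter from compound 1. Compound 3 `COc1ccc2[nH]cc(SC3CCN(C)CC3)c2c1` differs from compound 2 by methoxy in place of iodo on an aromatic carbon. Among the compounds with values here, no measured pair shows a change of this kind, so the expected step in this assay is of modest size, in either direction or none beyond the scatter, namely a 1.4-fold lower number from compound 2 to compound 3 (0.13 log units; within the scatter). For compound 3 the estimate in this assay is 40 mg/kg, within a range of 12 mg/kg to 130 mg/kg.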

Compound 3, dose for half-maximal effect: 24.9 mg/kg
Compound 3: middle estimate off by 1.6-fold (0.21 log units), on the high side, within the range that was stated.
By their numbers in this assay, from the lowest: compound 1; then compound 3; then compound 2.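

In this assay, methoxy in place of iodo on an aromatic carbon gives a 2.2-fold lower number from compound 2 to compound 3 (0.34 log units; beyond the scatter). Within the data shown here, this is the first reading of this position alone, as compound 1 and compound 2 differ in more than one place, and it shows that the group here can move the dose needed, though only modestly. Nothing available explains the step. From the compounds shown here alone, whether a hydroxyl group or an amine on the same carbon would move the number further remains open, as does whether this change would give a similar step in compound 1.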